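Lengthening the chain on the carbonyl of compound 3

The compounds below may be only part of what the source reports. "The series", "measured", "known", "first", "only" and "open" are said of these compounds alone.

In a functional assay on A549 cells (Homo sapiens) for inhibition, read by MTT assay, with a stated time of 72 h (on this read-out lower numbers stand for stronger inhibition and higher numbers for weaker inhibition), compound 3 (`CC/C=C\C(=O)Nc1cc(Nc2nc3c(c(-c4cn(C)c5ccccc45)n2)CSCC3)c(OC)cc1N(C)CCN(C)C`) gives 236 nM, the lowest of the three numbers. Compound 1 (`C=C(Cl)C(=O)Nc1cc(Nc2nc3c(c(-c4cn(C)c5ccccc45)n2)CSCC3)c(OC)cc1N(C)CCN(C)C`) gives 716 nM and compound 2 (`COc1cc(N(C)CCN(C)C)c(NC(=O)C=C(C)C)cc1Nc1nc2c(c(-c3cn(C)c4ccccc34)n1)CSCC2`) gives 583 nM. Compound 4 (`CCC/C=C\C(=O)Nc1cc(Nc2nc3c(c(-c4cn(C)c5ccccc45)n2)CSCC3)c(OC)cc1N(C)CCN(C)C`) turns but-1-en-1-yl into pent-1-en-1-yl: methyl in place of hydrogen on a saturated chain carbon, two bonds along the chain from a double-bonded chain carbon. The nearest evidence is a 3.0-fold lower number from compound 1 to compound 3 (0.48 log units; beyond the scatter) and a 2.5-fold lower number from compound 2 to compound 3 (0.39 log units; beyond the scatter), both modest, while a 1.2-fold lower number from compound 1 to compound 2 (0.09 log units; within the scatter) stays within the scatter. None of these steps is a simple chain extension, so they give no direction, and no step beyond the scatter is expected in this assay. The expected change is a 1.1-fold higher number from compound 3 to compound 4 (0.04 log units; within the scatter). The estimated value for compound 4 is 260 nM, with an expected range of 110 nM to 600 nM.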

Compound 4, half-maximal inhibitory concentration: 571 nM
For compound 4 the middle estimate is 2.2-fold (0.34 log units) below the measured one; the measured number falls inside the stated range.
By their numbers in this assay, from the lowest: compound 3; then compounds 4, 2 and 1 (each within the scatter of the next).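

In this assay, for the compounds shown here, the change from but-1-en-1-yl to pent-1-en-1-yl is the first simple chain extension, and the added methyl on this saturated chain carbon raises the number (a 2.4-fold higher number from compound 3 to compound 4 (0.38 log units; beyond the scatter)). Compound 4 therefore does not keep the standing of compound 3, and its number lies within the scatter of the other two (a 1.0-fold lower number from compound 2 to compound 4 (0.01 log units; within the scatter); a 1.3-fold lower number from compound 1 to compound 4 (0.10 log units; within the scatter)). Nothing available accounts for this rise. From the compounds shown here alone, whether a longer chain or an amine on this chain carbon would move the number further remains open.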